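This account rests on a few compounds, and the source may have more. Where it says the series, first, only, none or still open, it means among the compounds named here.

Compound 1 `COc1ccc(/C=C/C2CC(=O)C=CO2)cc1` and compound 3 `COc1ccc(/C=C/C2CC=CC(=O)O2)cc1` are built from the same atoms joined differently; the difference between their two cores is not broken down here. In a functional assay on MCF7 cells (Homo sapiens) for inhibition, read by sulforhodamine B assay, with a stated time of 48 h (on this read-out lower numbers stand for stronger inhibition of growth and higher numbers for weaker inhibition of growth), compound 1 gives 156 uM, while compound 3 gives 25.5 uM, the lowest of the three measured numbers, with both other compounds lying beyond the scatter from it. Compound 2 `COc1ccc(/C=C/C2CC(=O)C=CO2)cc1OC` differs from compound 1 in one place, (methoxy in place of hydrogen on an aromatic carbon). In this assay compound 2 gives 130 uM, a step of a 1.2-fold lower number from compound 1 to compound 2 (0.08 log units; within the scatter), which lies within the scatter.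

Compound 4 `COc1ccc(/C=C/C2CC=CC(=O)O2)cc1OC` has not been measured. It stands to compound 3 exactly as compound 2 stands to compound 1, (methoxy in place of hydrogen on an aromatic carbon), the same change at the same place, occurring twice among these compounds. The expectation for compound 4 rests on that single earlier instance. Because the step of a 1.2-fold lower number from compound 1 to compound 2 (0.08 log units; within the scatter) stayed within the scatter, the step from compound 3 is expected to be small as well, a 1.2-fold lower number from compound 3 to compound 4 (0.06 log units; within the scatter). Compound 4 is therefore expected to give 22 uM in this assay, most likely between 9 uM and 55 uM.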

Compound 4, concentration for growth inhibition (reported as GI): 7.8 uM
Compound 4: middle estimate off by 2.8-fold (0.45 log units), on the high side; measured number outside the range, below it.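

In this assay the added methoxy gives a 3.3-fold lower number from compound 3 to compound 4 (0.51 log units; beyond the scatter), a step beyond the scatter, whereas the earlier instance of the same change gave a 1.2-fold lower number from compound 1 to compound 2 (0.08 log units; within the scatter). The change therefore does not carry over at one size between the two cores: the same change on two cores in this assay, a 1.2-fold lower number (0.08 log units; within the scatter) from compound 1 to compound 2 and a 3.3-fold lower number (0.51 log units; beyond the scatter) from compound 3 to compound 4, 2.7-fold (0.44 log units) apart, beyond the scatter of two such steps

This rests on a single pair on each core, so it shows that the size of the step differed between these two cores, but it does not show why, nor how the change would behave on any further core.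

The compounds shown carry only hydrogen or methoxy at this place on the aromatic ring, which leaves open whether an ethoxy, a hydroxyl or a fluorine there would follow the step seen on either core. Also open, going by these compounds, is whether the two cores would part in the same way with an amine or a carboxylic acid in place of the methoxy.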